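Swapping the benzyl ether aryl group in a thiourea series

The compounds below may be only part of what the source reports. "The series", "measured", "known", "first", "only" and "open" are said of these compounds alone.

Measured so far:
- compound 1, `Cc1ccc(NC(=S)NC(=O)c2ccc(OCc3cccc(Cl)c3Cl)cc2)cc1-c1nc2ccccc2[nH]1`: > 100000 nM
- compound 2, `Cc1ccc(COc2ccc(C(=O)NC(=S)Nc3ccc(C)c(-c4nc5ccccc5[nH]4)c3)cc2)cc1`: 11300 nM

Of the compounds shown here, two sharing the same core have been measured in a functional assay on MNK45 cells (Homo sapiens) for inhibition, read by MTT assay, with a stated time of 48 h; on this read-out lower numbers stand for stronger inhibition and higher numbers for weaker inhibition. Compound 1 gives only a limit, > 100000 nM, so no number is known for it. For the measured compounds named here, compound 2 gives 11300 nM, the only number in the set. Compound 3, `Cc1ccc(NC(=S)NC(=O)c2ccc(OCc3ccc(Cl)cc3Cl)cc2)cc1-c1nc2ccccc2[nH]1`, has not yet been measured.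

The change from compound 2 to compound 3 is 2,4-dichlorophenyl in place of 4-methylphenyl on a saturated chain carbon bound to an oxygen on an aromatic ring. Going by the values given here, one measured step bears on it: an at least 8.8-fold lower number from compound 1 to compound 2 (0.94 log units; beyond the scatter), in which a dichlorophenyl was replaced by the 4-methylphenyl now being removed again. Because one of the two values sits at the limit of > 100000 nM in this assay, at which 1 of the 2 values shown sits, only a bound on that step is known.

The move from compound 2 to compound 3 runs in the opposite direction, toward a dichlorophenyl. Compound 3 is therefore expected to show a higher number than compound 2 in this assay, with a step of roughly a 4.4-fold higher number from compound 2 to compound 3 (0.65 log units; beyond the scatter). The estimate for compound 3 is 50000 nM, within 15000 nM to 150000 nM, and there is a fair chance that only a limit is reported.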

Compound 3, half-maximal inhibitory concentration: 5300 nM
Compound 3: middle estimate off by 9.4-fold (0.97 log units), on the high side, outside the stated range (below it).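

In this assay, the change from 4-methylphenyl to 2,4-dichlorophenyl on the saturated chain carbon gives a 2.1-fold lower number from compound 2 to compound 3 (0.33 log units; beyond the scatter), so two chlorines on this aryl group do not in themselves go with the loss seen for compound 1. The two dichlorophenyl isomers are instead separated by an at least 18-fold lower number from compound 1 to compound 3 (1.27 log units; beyond the scatter), which shows that at this place the outcome depends on how the chlorines are arranged and not only on their presence. Compound 1 gives a limit, > 100000 nM, and not a number, so the step from it can be read only as a bound: the limit of > 100000 nM in this assay, at which 1 of the 3 values shown sits.

The three compounds do not show whether one chlorine is enough, as in a 4-chlorophenyl group, or how a methoxy or trifluoromethyl group would compare with the chlorines and the methyl at this place. All three results also come from a single cell assay, which leaves open whether the same order would hold in other cells and what in the cells the compounds act on.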